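The compounds below may be only part of what the source reports. "The series", "measured", "known", "first", "only" and "open" are said of these compounds alone.

Compound 2 `O=[N+]([O-])c1ccc(S(=O)(=O)NC2=NCCN2C(=S)SN2CCn3c2nsc3=S)cc1` is one of two close analogues that share a core and differ only in the ring attached to the sulfonyl sulfur. In a functional assay on KYSE-510 cells (Homo sapiens) for antiproliferative activity, read by crystal violet staining, with a stated time of 96 h (a lower number here means a stronger inhibitor of growth, a higher number a weaker inhibitor of growth), compound 2 gives only a limit of the assay, >= 20000 nM. Its partner, compound 1 `Cc1ccc(S(=O)(=O)NC2=NCCN2C(=S)SN2CCn3c2nsc3=S)cc1`, carries a methyl in place of the nitro on the aromatic carbon. In this assay compound 1 likewise reaches only a limit, >= 20000 nM. Among the measured compounds shown here, the single measured step, a step that the two limits leave unreadable from compound 1 to compound 2, is therefore of unreadable size, and the one piece of evidence on it is the limit of >= 20000 nM in this assay, at which 2 of the 2 values shown sit. Compound 3 `O=S(=O)(NC1=NCCN1C(=S)SN1CCn2c1nsc2=S)c1ccccc1Cl` has not yet been measured; it differs from compound 2 by 2-chlorophenyl in place of 4-nitrophenyl on a sulfonyl sulfur. For the measured compounds named here, no measured step bears on this change in a readable way, and with both neighbours sitting at the limit the data give no direction for it. The expectation for compound 3 in this assay is that it too stays near the limit, giving an estimated 20000 nM with a range from 5000 nM to 60000 nM. The step this estimate means, a number no higher from compound 2 to compound 3 (the limit leaves the size open), is expected to be none beyond the scatter.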

Compound 3, concentration for 50% growth inhibition: >= 20000 nM
Compound 3: a limit, no number; the forecaster's own chance of this, stated with the estimate: 75%; the middle value sits exactly at the limit.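

Compound 3, like compound 1 and compound 2, gives only a limit in this assay, so no step among these three compounds can be read, and each size stays unknown: the limit of >= 20000 nM in this assay, at which 3 of the 3 values shown sit. On these data alone, how strongly any of the three compounds inhibits growth, and whether swapping the ring on the sulfonyl sulfur changes that at all, stays open.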